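Swapping nitro for amino at the far end of compound 2

The source may report more compounds than this note shows. Statements on the series, on what has been measured and on what is new or still open speak of the compounds shown alone.

Measured compounds:
Compound 1, `O=C(Nc1ccc(-c2ccc(C(=O)Nc3ccc(S(=O)(=O)O)c4ccccc34)cc2)cc1)c1ccc([N+](=O)[O-])cc1`: 2330 nM
Compound 2, `O=C(Nc1ccc(-c2ccc(C(=O)Nc3cccc4cccc(S(=O)(=O)O)c34)cc2)cc1)c1ccc([N+](=O)[O-])cc1`: 310 nM

Both compounds were tested in an assay on isolated protein for inhibition of CD40-CD40L (Homo sapiens), read by ELISA, with a stated time of 1 h; on this read-out lower numbers stand for stronger inhibition and higher numbers for weaker inhibition. Compound 2 gives 310 nM, the lowest of the two numbers; compound 1 gives 2330 nM, a gap that lies beyond the usual scatter of repeated measurements. The two differ only in where the sulfonic acid sits on the naphthalene ring, so this is all that can be read from the pair.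

Compound 3, `Nc1ccc(C(=O)Nc2ccc(-c3ccc(C(=O)Nc4cccc5cccc(S(=O)(=O)O)c45)cc3)cc2)cc1`, has not yet been measured. It keeps everything of compound 2 except at one end: amino in place of nitro on an aromatic carbon. Going by the values given here, no measured pair in this set shows the effect of that particular swap, so the direction of the step from compound 2 to compound 3 cannot be taken from any measured precedent. The step is expected to be small, probably within the scatter or slightly toward a higher number, giving a 1.9-fold higher number from compound 2 to compound 3 (0.29 log units; within the scatter). Compound 3 is therefore expected to give about 600 nM, somewhere between 150 nM and 2500 nM.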

Compound 3, half-maximal inhibitory concentration: 301000 nM
Compound 3: middle estimate off by 500-fold (2.70 log units), on the low side, and the stated range ends below it.
By their numbers in this assay, from the lowest: compound 2; then compound 1; then compound 3.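

In this assay, amino in place of nitro on an aromatic carbon, para to a large group, brings a 970-fold higher number from compound 2 to compound 3 (2.99 log units; beyond the scatter) and so a large loss of inhibition from this one change. Compound 1 and compound 2 showed only that the place of the sulfonic acid counts, whereas this pair shows that the 4-nitrophenyl to 4-aminophenyl change at the other end of the molecule counts too, and that this position is far from indifferent to what it carries. Nothing measured alongside these numbers explains the loss.

One swap cannot tell whether nitro is specially favourable here or amino is specially harmful, since both groups change at once and only these two have been seen at this position. A nitrile, a carboxylic acid or a methyl group on the same carbon, or a bare hydrogen there, could separate those two readings by showing whether the number stays close to that of compound 2 or climbs toward that of compound 3.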